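A few compounds are considered here, and "the series" means these few. Any claim that something is new, unique, unknown or untested is made for them only; others in the source may bear on it.

In a functional assay on A2780 cells (Homo sapiens) for antiproliferative activity, read by CellTiter-Glo, with a stated time of 4 days (on this read-out higher numbers stand for weaker inhibition and lower numbers for stronger inhibition), compound 1 `O=C(CCc1cccnc1)Nc1ccc(CN2C(=O)c3ccccc3C2=O)cc1` reads > 10000 nM as a limit of the assay and not a number. Compound 2 `CCC(=O)N[C@@H](C)c1ccc(NC(=O)[C@H]2C[C@@H]2c2cccnc2)cc1` gives 5 nM and holds the lower of the two actual numbers in the series. Compound 3 `CC[C@H](NC(=O)c1ccccc1)c1ccc(NC(=O)[C@H]2C[C@@H]2c2cccnc2)cc1` gives 43 nM as the higher of the two, and the gap to compound 2 lies beyond the scatter.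

Compound 4 `COCC(=O)N[C@@H](C)c1ccc(NC(=O)[C@H]2C[C@@H]2c2cccnc2)cc1` carries methoxy in place of methyl on a saturated chain carbon bound to a carbonyl carbon and otherwise matches compound 2. Within the data shown here, no measured step isolates this change. Compound 3 has another group on the same carbonyl and still gives 43 nM, so a change on this side need not cost much. In this assay a small step toward a higher number is expected, near the edge of the scatter. The estimated step of a 1.6-fold higher number from compound 2 to compound 4 (0.20 log units; within the scatter) stays modest in size. For compound 4 the expected value is 8 nM with an estimated range from 3 nM to 25 nM in this assay.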

Compound 4, half-maximal inhibitory concentration: 30 nM
Beside the measured number, compound 4's estimate is 3.8-fold (0.57 log units) below it; the measured number lies above the stated range.
By their numbers in this assay, from the lowest: compound 2; then compounds 4 and 3 (each within the scatter of the next). At a limit, above all of these: compound 1.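

In this assay, methoxy in place of methyl on a saturated chain carbon bound to a carbonyl carbon gives a 6.0-fold higher number from compound 2 to compound 4 (0.78 log units; beyond the scatter), the only single-place step among the compounds shown. This position therefore does not tolerate every change freely, even one that adds only 2 heavy atoms in place of 1 and brings in 1 hydrogen-bond acceptor, although compound 4 still gives 30 nM. Nothing measured here gives a reason for this step.

The compounds shown do not separate the effect of the oxygen atom from that of the added chain length, and a longer all-carbon chain at this carbon would make that comparison. From the compounds shown here alone, how a hydroxyl or an amine would read at the same carbon also remains open.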